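This account rests on a few compounds, and the source may have more. Where it says the series, first, only, none or still open, it means among the compounds named here.

Notes on the series in a functional assay with Homo sapiens as the target; on this read-out lower numbers stand for stronger inhibition and higher numbers for weaker inhibition. Compound 1 `CC(C)[C@H](NC(=O)COc1cccc2ccccc12)C(=O)N[C@@H](CC(=O)O)C(=O)COc1ccccc1` gives 11200 nM, compound 3 `CC(C)[C@H](NC(=O)COc1cccc2ccccc12)C(=O)N[C@@H](CC(=O)O)C(=O)COc1ccc([N+](=O)[O-])cc1` gives 22800 nM, and compound 2 `CC(C)[C@H](NC(=O)COc1cccc2ccccc12)C(=O)N[C@@H](CC(=O)O)C(=O)COc1ccc(-c2ccccc2)cc1` gives 38700 nM. Compound 2 holds the highest number of the three, but it is not separated from compound 3: the gap is a 1.7-fold lower number from compound 2 to compound 3 (0.23 log units; within the scatter). It does stand clear of compound 1, with a 3.5-fold higher number from compound 1 to compound 2 (0.54 log units; beyond the scatter).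

The next compound is compound 4 `CC(C)[C@H](NC(=O)COc1cccc2ccccc12)C(=O)N[C@@H](CC(=O)O)C(=O)COc1ccccc1F`, and the change is 2-fluorophenyl in place of 4-phenylphenyl on an oxygen on a saturated carbon. Within the data shown here, no measured compound carries fluorine, so that atom's contribution is unknown. The best guide is a 3.5-fold higher number from compound 1 to compound 2 (0.54 log units; beyond the scatter), read in reverse, since compound 4 loses the same added phenyl. The nitro step, a 2.0-fold higher number from compound 1 to compound 3 (0.31 log units; beyond the scatter), is also modest, so compound 1 at 11200 nM is the expected reference point. A modest move to a lower number is therefore expected, estimated as a 3.2-fold lower number from compound 2 to compound 4 (0.51 log units; beyond the scatter). For compound 4 the estimated value is 12000 nM, with an expected range of 4500 nM to 30000 nM.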

Compound 4, half-maximal inhibitory concentration: 15700 nM
The estimate for compound 4 lay 1.3-fold (0.12 log units) below the measured number, and the stated range covers the measured number.
By their numbers in this assay, from the lowest: compounds 1, 4, 3 and 2 (each within the scatter of the next, the first and the last beyond it).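

Among these compounds, the 2-fluorophenyl group is the first replacement for the unsubstituted phenyl of compound 1 whose step lies within the scatter (a 1.4-fold higher number from compound 1 to compound 4 (0.15 log units; within the scatter)), while the phenyl and nitro steps from compound 1 lie beyond it. On an oxygen on a saturated carbon, exchanging 4-phenylphenyl for 2-fluorophenyl gives a step beyond the scatter (a 2.5-fold lower number from compound 2 to compound 4 (0.39 log units; beyond the scatter)), but exchanging 4-nitrophenyl for 2-fluorophenyl does not (a 1.5-fold lower number from compound 3 to compound 4 (0.16 log units; within the scatter)), so compound 4 is separated from compound 2 and not from compound 3. No measurement here accounts for these differences.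

On these data alone, whether an amine or a carboxylic acid on the phenyl group would bring the number below that of compound 1 remains open. As far as these compounds go, the effect of changes elsewhere also remains open, as all four compounds share the same core and differ only in the group on that oxygen.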